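The compounds below may be only part of what the source reports. "The series", "measured", "known", "first", "only" and "open" are said of these compounds alone.

Measured so far:
compound 1, `Brc1cn2ccnc2c(-c2ccc3ncn(C4CCCCC4)c3c2)n1`, 11.5%
compound 2, `c1ccc(-c2cn3ccnc3c(-c3ccc4ncn(C5CCCCC5)c4c3)n2)cc1`, 35.9%
compound 3, `COc1ccc(-c2cn3ccnc3c(-c3ccc4ncn(C5CCCCC5)c4c3)n2)cc1`, 61%

In a functional assay on ACHN cells (Homo sapiens) for inhibition, read by sulforhodamine B assay, with a stated time of 48 h, tested at 10 uM (a lower number here means less inhibition, a higher number more inhibition at the concentration tested (going by the name of the read-out)), compound 3 gives the highest of the three numbers; compound 2 lies a number 25.1 percentage points higher from compound 2 to compound 3 (beyond the scatter), and compound 1 lies a number 49.5 percentage points higher from compound 1 to compound 3 (beyond the scatter). Compound 4, `O=Cc1ccc(-c2cn3ccnc3c(-c3ccc4ncn(C5CCCCC5)c4c3)n2)cc1`, has not yet been measured in this assay. It differs from compound 3 in one place: formyl in place of methoxy on an aromatic carbon, so that 4-methoxyphenyl becomes 4-formylphenyl.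

Within the data shown here, none of the measured steps swaps one group for another on this ring; the closest is the step of a number 25.1 percentage points higher from compound 2 to compound 3 (beyond the scatter), where methoxy replaced hydrogen, and the earlier steps of a number 24.4 percentage points higher from compound 1 to compound 2 (beyond the scatter) and a number 49.5 percentage points higher from compound 1 to compound 3 (beyond the scatter), which put the phenyl group in place at all. Compound 4 keeps the phenyl group, so the large part of the effect seen in compound 2 and compound 3 should remain, but whether formyl matches methoxy is not shown by any step. A modest fall toward compound 2 is therefore the expected size of a number 16 percentage points lower from compound 3 to compound 4 (beyond the scatter). Compound 4 is expected to give about 45% in this assay, within a range from 20% to 70%.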

Compound 4, a percentage reported as inhibition, at one concentration (the size of the read-out at that concentration, not a potency): 11.6%
Beside the measured number, compound 4's estimate is 33.4 percentage points above it, and the stated range ends above it.
By their numbers in this assay, from the lowest: compounds 1 and 4 (each within the scatter of the next); then compound 2; then compound 3.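

In this assay the phenyl group does not carry the result by itself, and the group on it matters in both directions: formyl in place of methoxy gives a number 49.4 percentage points lower from compound 3 to compound 4 (beyond the scatter) and formyl in place of hydrogen gives a number 24.3 percentage points lower from compound 2 to compound 4 (beyond the scatter) on the same ring. The 4-formylphenyl group also shows no separation from bromo, with a number 0.1 percentage points higher from compound 1 to compound 4 (within the scatter) in this comparison, so the earlier gain from the phenyl group is absent here. Methoxy and formyl have the same counts of heavy atoms and hydrogen-bond acceptors, and nothing shown here explains why they differ.

As far as these compounds go, whether this loss is specific to formyl remains open, and an amine, a nitrile or a carboxylic acid on the same carbon would test that. Readings at a single concentration also leave the potency of these compounds open.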